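The compounds below may be only part of what the source reports. "The series", "measured", "known", "first", "only" and "open" are said of these compounds alone.

The three measured compounds share one core and differ only in the aromatic ring attached to it. Compound 1 `c1ccc(-c2ccncc2)c(OCC2=NCCN2)c1` carries a pyridin-4-yl group. In a functional assay for activation of Alpha-1B adrenergic receptor (Homo sapiens), read by calcium flux (on this read-out lower numbers stand for an effect already at smaller amounts and higher numbers for an effect only at larger amounts of compound), compound 1 gives only a limit, < 100000 nM, which is not a number (the limit of < 100000 nM in this assay, at which 1 of the 3 values shown sits). Compound 2 `c1csc(-c2ccccc2OCC2=NCCN2)c1` carries a thiophen-2-yl group, and in this assay compound 2 gives 3.98 nM. Compound 3 `c1ccc(-c2ccsc2)c(OCC2=NCCN2)c1` carries a thiophen-3-yl group, and in this assay compound 3 gives 15.9 nM, the highest of the two readable numbers. Among the measured compounds shown here, the steps a step that the limit leaves unreadable from compound 1 to compound 2 and a step that the limit leaves unreadable from compound 1 to compound 3 cannot be sized, so the only readable step is a 4.0-fold higher number from compound 2 to compound 3 (0.60 log units; beyond the scatter).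

Compound 4 `Cc1ccoc1-c1ccccc1OCC1=NCCN1` is not yet measured. It differs from compound 3 in one place: 3-methylfuran-2-yl in place of thiophen-3-yl on an aromatic carbon. The new ring is named like thiophen-2-yl rather than thiophen-3-yl, and the step of a 4.0-fold higher number from compound 2 to compound 3 (0.60 log units; beyond the scatter) shows that this kind of change in attachment mattered modestly. For the measured compounds named here, no measured step covers the exchange of sulfur for oxygen or the added methyl, so those parts of the change carry no guidance. The expectation for compound 4 is therefore a modest drop in the number, a 2.7-fold lower number from compound 3 to compound 4 (0.42 log units; beyond the scatter), with a wide range. The estimate for compound 4 in this assay is 6 nM, between 1.5 nM and 25 nM.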

Compound 4, half-maximal effective concentration: < 100000 nM
Compound 4: no number, only a limit; the forecaster's own chance of this, stated with the estimate: 2%; the middle value lies beyond the limit too.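

In this assay compound 4 gives only a limit, < 100000 nM, and not a number, so none of its steps from compound 1, compound 2 or compound 3 can be read. The compounds shown leave open whether the furan oxygen in place of sulfur or the added methyl of 3-methylfuran-2-yl governs this result.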